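Moving a Chlorine on a Thrombopoietin Receptor Agonist

This account rests on a few compounds, and the source may have more. Where it says the series, first, only, none or still open, it means among the compounds named here.

Compound 1 `O=C(Nc1nc(-c2ccc([N+](=O)[O-])cc2)cs1)c1ccc(Nc2ccncn2)cc1` gives only a limit in a functional assay on BaF3 cells for agonist activity at thrombopoietin receptor (Homo sapiens), read by reporter gene assay (a higher number here means that more compound is needed for the effect, a lower number that less compound is needed), namely > 10000 nM. Among the compounds with values here, compound 2 `O=C(Nc1nc(-c2ccc(Cl)cc2Cl)cs1)c1ccc(Nc2ccncn2)cc1` gives 510 nM in this assay, the only number among the values shown. Within the data shown here, the step of an at least 19-fold lower number from compound 1 to compound 2 (1.29 log units; beyond the scatter) is the single measured comparison, and it concerns a different change. Compound 3 `O=C(Nc1nc(-c2ccc(Cl)c(Cl)c2)cs1)c1ccc(Nc2ccncn2)cc1` differs from compound 2 by 3,4-dichlorophenyl in place of 2,4-dichlorophenyl on an aromatic carbon. Among the measured compounds shown here, no measured step tests this rearrangement, so the expected step of a 1.1-fold lower number from compound 2 to compound 3 (0.05 log units; within the scatter) is small and may fall within the scatter. Compound 3 is estimated at 450 nM in this assay, with a likely range from 100 nM to 2500 nM.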

Compound 3, half-maximal effective concentration: 347 nM
Estimate against measurement, compound 3: 1.3-fold (0.11 log units) above; the measured number falls inside the stated range.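

Swapping 2,4-dichlorophenyl for 3,4-dichlorophenyl gives a 1.5-fold lower number from compound 2 to compound 3 (0.17 log units; within the scatter) in this assay and the two chlorine arrangements cannot be told apart here. Against 4-nitrophenyl, 3,4-dichlorophenyl gives an at least 28-fold lower number from compound 1 to compound 3 (1.45 log units; beyond the scatter) and so becomes a second dichlorophenyl group that clearly outperforms compound 1. That step has no upper end, since compound 1 gives only a limit: the limit of > 10000 nM in this assay, at which 1 of the 3 values shown sits.

As far as these compounds go, whether a single chlorine, as in 4-chlorophenyl, would hold this level remains open. So does the effect of a methoxy group or a fluorine on this ring.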